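Toward a 3-methylphenyl analogue in a piperazine-linked oxazole series

The source may report more compounds than this note shows. Statements on the series, on what has been measured and on what is new or still open speak of the compounds shown alone.

Measured compounds:
compound 1, `CCCc1nc(-c2ccccc2)c(CNCCCN2CCN(c3ccccc3)CC2)o1`, 43.7%;
compound 2, `CCCc1nc(-c2ccccc2)c(CNCCCN2CCN(c3ccccc3OC)CC2)o1`, 41%;
compound 3, `CCCc1nc(-c2ccccc2)c(CNCCN2CCN(c3ccc(C)cc3)CC2)o1`, 48.1%.

In an assay on HEK293 cells for inhibition of Voltage-dependent T-type calcium channel subunit alpha-1G (Homo sapiens), read by fluorescence, tested at 10 uM (a lower number here means less inhibition, a higher number more inhibition at the concentration tested (going by the name of the read-out)), compound 2 gives the lowest of the three numbers, yet it sits within the scatter of both neighbours: compound 1 lies closest, and compound 3 furthest, neither separated from it by more than the usual spread. For the measured compounds named here, the one single-point step recorded, a number 2.7 percentage points lower from compound 1 to compound 2 (within the scatter), changes methoxy in place of hydrogen on an aromatic carbon and stays within the scatter. Compound 3 differs from compound 2 in more than one place, so only its value can be compared.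

Compound 4, `CCCc1nc(-c2ccccc2)c(CNCCCN2CCN(c3cccc(C)c3)CC2)o1`, is the next compound to be measured. It differs from compound 2 by 3-methylphenyl in place of 2-methoxyphenyl on an amine nitrogen in a ring. Going by the values given here, the only step that bears on it is the small one from compound 1 to compound 2, so no change beyond the scatter is expected in this assay. Compound 4 is therefore estimated to give about 45%, between 34% and 56%, a step of a number 4 percentage points higher from compound 2 to compound 4 (within the scatter).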

Compound 4, a percentage reported as inhibition, at one concentration (the size of the read-out at that concentration, not a potency): 47.8%
The estimate for compound 4 lay 2.8 percentage points below the measured number; the range from low to high includes it.
By their numbers in this assay, from the lowest: compounds 2, 1, 4 and 3 (each within the scatter of the next).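

In this assay, the change at this position, with the new aryl group three ring bonds from the ring nitrogen, gives a number 6.8 percentage points higher from compound 2 to compound 4 (within the scatter), and adding a methyl group to the unsubstituted phenyl gives a number 4.1 percentage points higher from compound 1 to compound 4 (within the scatter). With the earlier step, a number 2.7 percentage points lower from compound 1 to compound 2 (within the scatter), all three aryl groups in this single-change set, phenyl, 2-methoxyphenyl and 3-methylphenyl, now stand within the scatter of one another, so neither a methyl nor a methoxy substituent separates from the unsubstituted phenyl here. No independent measurement bears on why these numbers lie so close.

For the compounds shown here, whether an amine or a carboxylic acid on this aromatic ring, or a longer chain in place of the one shared by compound 1, compound 2 and compound 4, would move the number beyond the scatter stays open. A reading at one concentration also gives no potency for any of these compounds.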